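Working notes on a Bcl-2 binding series

This account rests on a few compounds, and the source may have more. Where it says the series, first, only, none or still open, it means among the compounds named here.

Two compounds have so far been measured in an assay on isolated protein for displacement of a labelled ligand from Apoptosis regulator Bcl-2 (Homo sapiens), read by fluorescence polarization; on this read-out higher numbers stand for weaker inhibition and lower numbers for stronger inhibition:
compound 1 (`COc1ccccc1CC1(OC)CCN(c2ccc(C(=O)NS(=O)(=O)c3ccc(N[C@H](CCN(C)C)CSc4ccccc4)c([N+](=O)[O-])c3)cc2)CC1`): 1.6 nM
compound 2 (`CN(C)CC[C@H](CSc1ccccc1)Nc1ccc(S(=O)(=O)NC(=O)c2ccc(N3CCC(=Cc4ccccc4Cl)CC3)cc2)cc1[N+](=O)[O-]`): 0.7 nM

Compound 2 stands lowest of the two numbers in this assay; the nearest is compound 1, whose number is higher by a margin beyond the usual scatter. For the measured compounds named here, compounds 1 and 2 differ in more than one place, so no single step between them can be read; only the two values themselves are on hand.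

Compound 3 (`CN(C)CC[C@H](CSc1ccccc1)Nc1ccc(S(=O)(=O)NC(=O)c2ccc(N3CCC(=Cc4cccnc4)CC3)cc2)cc1[N+](=O)[O-]`) has not yet been measured in this assay. It differs from compound 2 in one place: pyridin-3-yl in place of 2-chlorophenyl on a double-bonded chain carbon bound to a double-bonded ring carbon. Going by the values given here, no step between measured compounds is available to guide this change, so the expectation rests on the structural change alone. For compound 3 the expected step is a 2.1-fold higher number from compound 2 to compound 3 (0.33 log units; beyond the scatter), a small shift toward a higher number that may well not exceed the scatter. For compound 3 the estimated value in this assay is 1.5 nM, with a range from 0.5 nM to 5 nM.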

Compound 3, inhibition constant: 68 nM
For compound 3 the middle estimate is 45-fold (1.66 log units) below the measured one; measured number outside the range, above it.
By their numbers in this assay, from the lowest: compound 2; then compound 1; then compound 3.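

In this assay, for the compounds shown here, pyridin-3-yl in place of 2-chlorophenyl on a double-bonded chain carbon bound to a double-bonded ring carbon gives a 97-fold higher number from compound 2 to compound 3 (1.99 log units; beyond the scatter), so the number at this position depends strongly on the aromatic ring it carries, which the earlier compounds, differing in more than one place, could not show. The change is confined to that ring: a ring of carbon only bearing a chlorine leaves, and a ring with one hetero atom and one hydrogen-bond acceptor enters, while the rest of the structure stays the same. Nothing measured on hand bears on why the number rises so far.

Going by these compounds alone, the single step changes the chlorine and the ring nitrogen together, so an unsubstituted phenyl at this position would be needed to show how much of the step goes with each. Also open, going by these compounds, are whether a methyl or a methoxy group in place of the chlorine would hold the number near that of compound 2, and whether pyridin-2-yl or pyridin-4-yl would give a step of similar size.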